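Ester Chain Length and Cytotoxicity in a Shared Core

A few compounds are considered here, and "the series" means these few. Any claim that something is new, unique, unknown or untested is made for them only; others in the source may bear on it.

Compound 1 `CCCCCOC(=O)CCC(=O)N1CCN(CCCOc2cc3c(Nc4ccc(F)c(Cl)c4)ncnc3cc2OC)CC1`: 63.6%
Compound 2 `CCCCCCCCCCCCOC(=O)CCC(=O)N1CCN(CCCOc2cc3c(Nc4ccc(F)c(Cl)c4)ncnc3cc2OC)CC1`: 5.7%
Compound 3 `CCCCCCCCCCCCCOC(=O)CCC(=O)N1CCN(CCCOc2cc3c(Nc4ccc(F)c(Cl)c4)ncnc3cc2OC)CC1`: 71.1%

In a functional assay on A549 cells (Homo sapiens) for cytotoxicity, read by MTT assay, with a stated time of 24 h, tested at 40 uM (a higher number here means a weaker effect of the compound at the concentration tested, a lower number a stronger effect), compound 3 stands close to compound 1, since a number 7.5 percentage points higher from compound 1 to compound 3 (within the scatter), while both lie far from compound 2, as a number 65.4 percentage points higher from compound 2 to compound 3 (beyond the scatter) shows. Compound 4 `CCCCCCCCCCCCCCCCOC(=O)CCC(=O)N1CCN(CCCOc2cc3c(Nc4ccc(F)c(Cl)c4)ncnc3cc2OC)CC1` differs from compound 3 by propyl in place of hydrogen on a saturated chain carbon, ten or more bonds along the chain from an oxygen next to a carbonyl group. The step at the same place, a number 65.4 percentage points higher from compound 2 to compound 3 (beyond the scatter), ran opposite to a number 57.9 percentage points lower from compound 1 to compound 2 (beyond the scatter), so the three measured numbers give no consistent direction for growing the chain further, and the expected step in this assay is small, with wide uncertainty either way. Compound 4 is therefore expected to give 58%, between 15% and 90%, an estimated step of a number 13.1 percentage points lower from compound 3 to compound 4 (beyond the scatter).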

Compound 4, a percentage reported as activity, at one concentration (the size of the read-out at that concentration, not a potency): 82.6%
The estimate for compound 4 lay 24.6 percentage points below the measured number, within the range that was stated.
By their numbers in this assay, from the lowest: compound 2; then compounds 1 and 3 (each within the scatter of the next); then compound 4.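

In this assay, extending the chain beyond compound 3 did not bring back the strong effect of compound 2: a number 76.9 percentage points higher from compound 2 to compound 4 (beyond the scatter), and compound 4 shows the weakest effect of the four, with a number 11.5 percentage points higher from compound 3 to compound 4 (beyond the scatter) and a number 19 percentage points higher from compound 1 to compound 4 (beyond the scatter). Compound 2 remains the only one with a low number, so the long chains shown follow no steady trend with length. Nothing available here explains this course along the chain.

On these data alone, it remains open whether chains just shorter or longer than that of compound 2 also give a low number. As far as these compounds go, how a carboxylic acid in place of the ester, or a still longer chain, would read in this assay also remains open.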